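The compounds below may be only part of what the source reports. "The series", "measured", "known", "first", "only" and "open" are said of these compounds alone.

Among the measured compounds shown here, compound 1 `COc1cc(/C=C/C(=O)c2cccc(-n3cc(-c4ccccc4)[nH]c3=O)c2)ccc1O` gives 2920 nM in a functional assay on NCI/ADR-RES cells (Homo sapiens) for inhibition (on this read-out lower numbers stand for stronger inhibition of growth and higher numbers for weaker inhibition of growth), the lower of the two numbers so far. Compound 2 `O=C(/C=C/c1cccc(O)c1)c1cccc(-n2cc(-c3ccccc3)[nH]c2=O)c1` gives 3730 nM in this assay, and the step of a 1.3-fold higher number from compound 1 to compound 2 (0.11 log units; within the scatter) shows that exchanging the aryl on the chain changes little. Compound 3 `COc1ccc(-c2cn(-c3cccc(C(=O)/C=C/c4ccc(O)c(OC)c4)c3)c(=O)[nH]2)cc1` differs from compound 1 by methoxy in place of hydrogen on an aromatic carbon, on the phenyl of the core rather than on the chain aryl. For the measured compounds named here, no measured step touches that phenyl; the one step at hand was within the scatter, so no shift beyond the scatter is expected for compound 3, about a 1.0-fold lower number from compound 1 to compound 3 (0.00 log units; within the scatter), estimated at 2900 nM (range 1200 nM to 7000 nM).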

Compound 3, concentration for 50% growth inhibition: 2560 nM
The estimate for compound 3 lay 1.1-fold (0.05 log units) above the measured number; measured number inside the range.
By their numbers in this assay, from the lowest: compounds 3, 1 and 2 (each within the scatter of the next).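

The phenyl of the core, unchanged until now, accepts a methoxy para to a large group, phenyl to 4-methoxyphenyl, with a 1.1-fold lower number from compound 1 to compound 3 (0.06 log units; within the scatter) in this assay. So this position, like the chain aryl with a 1.3-fold higher number from compound 1 to compound 2 (0.11 log units; within the scatter), has so far given no step beyond the scatter. Nothing available accounts for this result.

As far as these compounds go, whether an amine or a carboxylic acid on this phenyl would move the number beyond the scatter remains open. The same holds for a methoxy elsewhere on that ring.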